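The source may hold more compounds than are shown below. What is called first, only, known or untested is meant among the compounds shown, and "the series" means these compounds.

Measured in an ADME assay on Huh7.5.1 cells (Homo sapiens) for cytotoxicity, read by WST assay, with a stated time of 48 h; a lower number here means that less compound is tolerated, a higher number that more compound is tolerated:
- Compound 1 `CN=S(=O)(c1ccc(Cc2ccc(-c3[nH]c4cccc(F)c4c(=O)c3C)cc2)cc1)C(F)(F)F`: > 10000 nM, a limit
- Compound 2 `Cc1c(-c2ccc(Cc3ccc(S(F)(F)(F)(F)F)cc3)cc2)[nH]c2cccc(F)c2c1=O`: > 5000 nM, a limit
- Compound 3 `Cc1c(-c2ccc(Oc3ccc(SC(F)(F)F)cc3)c(F)c2)[nH]c2cccc(F)c2c1=O`: > 10000 nM, a limit

None of the three compounds has an exact value. Compound 3 sits at the limit of > 10000 nM in this assay, at which 2 of the 3 values shown sit, and compound 2 sits at the limit of > 5000 nM in this assay, at which 1 of the 3 values shown sits.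

Compound 4 `Cc1c(-c2ccc(Oc3ccc(N(C)C)cc3)c(F)c2)[nH]c2cccc(F)c2c1=O` carries dimethylamino in place of (trifluoromethyl)sulfanyl on an aromatic carbon, para to a large group: dimethylamino in place of (trifluoromethyl)sulfanyl on an aromatic carbon. Going by the values given here, the only measured step, a step that the two limits leave unreadable from compound 1 to compound 2, exchanges other groups and gives no size to carry over. In this assay, no direction can therefore be argued, and the expected change is none beyond the scatter: a number no higher from compound 3 to compound 4 (the limit leaves the size open). Compound 4 is estimated at 10000 nM, with an expected range from 3000 nM to 20000 nM.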

Compound 4, half-maximal cytotoxic concentration: > 10000 nM
Compound 4 gave a limit, no number; the forecaster's own chance of this, stated with the estimate: 65%; the middle value sits exactly at the limit.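

Compound 3 and compound 4 both stay at limits in this assay, so the step between them cannot be read. The compounds shown leave open whether dimethylamino in place of (trifluoromethyl)sulfanyl changes the half-maximal cytotoxic concentration at all.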